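Hydroxy in Place of Methoxy: Expected Tolerance Shift

The source may report more compounds than this note shows. Statements on the series, on what has been measured and on what is new or still open speak of the compounds shown alone.

Measured so far:
- compound 1, `O=C(Nc1cccc(-n2cc(-c3ccncc3)c(-c3ccc(Cl)c(O)c3)n2)c1)Nc1cccc(C(F)(F)F)c1`, > 32500 nM
- compound 2, `COc1cc(-c2nn(-c3cccc(NC(=O)Nc4cc(C(F)(F)F)cc(C(F)(F)F)c4)c3)cc2-c2ccncc2)ccc1Cl`, 3390 nM

The two compounds share a core and differ in two places: the substituent on the oxygen of the aryl ring and the number of trifluoromethyl groups on the urea-linked phenyl. Among the measured compounds shown here, in a functional assay on OVCAR-3 cells (Homo sapiens) for inhibition, read by sulforhodamine B assay, with a stated time of 48 h (a higher number here means that more compound is tolerated, a lower number that less compound is tolerated), compound 2 gives 3390 nM, and that is the only plain number available. For compound 1 this assay reports only a limit, > 32500 nM, so no number is known; as the evidence states, (the limit of > 32500 nM in this assay, at which 1 of the 2 values shown sits).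

Compound 3, `O=C(Nc1cccc(-n2cc(-c3ccncc3)c(-c3ccc(Cl)c(O)c3)n2)c1)Nc1cc(C(F)(F)F)cc(C(F)(F)F)c1`, keeps the bis-trifluoromethyl phenyl of compound 2 and changes one thing: hydrogen in place of methyl on an oxygen on an aromatic ring. Compound 1 also carries the 4-chloro-3-hydroxyphenyl group, and for it only a limit is shown, which gives no firm reading on this change alone, but offers no sign that the hydroxy form is better tolerated.

With so little to go on, the expected step from compound 2 to compound 3 is a 2.4-fold higher number from compound 2 to compound 3 (0.37 log units; beyond the scatter), leaning toward more compound being tolerated. Compound 3 is therefore expected to give about 8000 nM, within a range of 2500 nM to 32500 nM, with a real chance that this assay again reports only a limit.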

Compound 3, concentration lethal to 50% of the cells: 3310 nM
Compound 3: the middle estimate sits 2.4-fold (0.38 log units) above what was measured; measured number inside the range.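

Swapping methoxy for hydroxy, with hydrogen in place of methyl on an oxygen on an aromatic ring, gives a 1.0-fold lower number from compound 2 to compound 3 (0.01 log units; within the scatter) in this assay. Compounds 1 and 2 could not show this, as they differ in two places, whereas this pair differs in one: here, the methoxy and hydroxy forms cannot be told apart in this read-out. With the hydroxy group held fixed, trifluoromethyl in place of hydrogen on an aromatic carbon gives an at least 9.8-fold lower number from compound 1 to compound 3 (0.99 log units; beyond the scatter), and the size of that step is only a lower bound, resting on a limit for compound 1: the limit of > 32500 nM in this assay, at which 1 of the 3 values shown sits.

The compounds shown leave open whether the methoxy-to-hydroxy swap would also leave the read-out unchanged with only one trifluoromethyl group on the urea-linked phenyl, and whether the second trifluoromethyl group has the same effect when methoxy replaces hydroxy. They also leave open how far this oxygen can be changed, for instance whether an amine or a carboxylic acid in its place, or a longer chain such as ethoxy or propoxy, would shift the result.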